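Thiosemicarbazide series: morpholine in place of thiomorpholine

A few compounds are considered here, and "the series" means these few. Any claim that something is new, unique, unknown or untested is made for them only; others in the source may bear on it.

Compound 1 `Cc1cccc(/C(N)=N/NC(=S)N2CCSCC2)n1` and compound 2 `Cc1cccc(/C(N)=N/NC(=S)N2CCOCC2)n1` share one core, while compound 3 `N/C(=N\NC(=S)N1CCSCC1)c1ccc(F)cn1` and the still unmeasured compound 4 `N/C(=N\NC(=S)N1CCOCC1)c1ccc(F)cn1` share another; how the two cores differ from each other is not broken down here. In a functional assay on MCF7 cells (Homo sapiens) for cytotoxicity, read by MTT assay, with a stated time of 72 h, tested at 3 uM (on this read-out higher numbers stand for more inhibition of growth at the one concentration tested and lower numbers for less inhibition of growth), compound 1 gives 20.6% and compound 2 gives 21.6%. For the measured compounds named here, the step of a number 1 percentage points higher from compound 1 to compound 2 (within the scatter) belongs to the change morpholin-4-yl in place of thiomorpholin-4-yl on a thiocarbonyl carbon and is the only measured instance of that change so far. In this assay compound 3 gives 35.4%, the highest of the three measured numbers, and its distance from both compound 2 and compound 1 lies beyond the usual scatter.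

Going by the values given here, compound 4 is reached from compound 3 by morpholin-4-yl in place of thiomorpholin-4-yl on a thiocarbonyl carbon, which is the same change at the same kind of position as the one from compound 1 to compound 2, with the thiocarbonyl carbon carrying an amide-type nitrogen as its other neighbour in both pairs. Among the compounds with values here, with only one measured instance to rest on, the expectation for compound 4 is that the step of a number 0.6 percentage points higher from compound 3 to compound 4 (within the scatter) will be expected to stay within the scatter, because the measured step of a number 1 percentage points higher from compound 1 to compound 2 (within the scatter) was itself within the scatter. On that basis compound 4 is expected to give about 36% in this assay, with a likely range from 25% to 47%.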

Compound 4, percent growth inhibition at one concentration: 33.9%
For compound 4 the middle estimate is 2.1 percentage points above the measured one; measured number inside the range.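

In this assay, morpholin-4-yl in place of thiomorpholin-4-yl on a thiocarbonyl carbon gives a number 1.5 percentage points lower from compound 3 to compound 4 (within the scatter), and this agrees with the earlier instance of the change on the other core: the same change on two cores in this assay, a number 1 percentage points higher (within the scatter) from compound 1 to compound 2 and a number 1.5 percentage points lower (within the scatter) from compound 3 to compound 4, 2.5 percentage points apart, within the scatter of two such steps On these two cores the change therefore carries over in the same way, with neither step leaving the scatter, so the two rings cannot be told apart on this read-out in either pair. This does not show that the two rings are interchangeable in general: the finding rests on two pairs, one cell line and a single concentration, and a difference might still appear on a further core or over a full concentration range.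

The compounds shown leave open whether other groups on the thiocarbonyl carbon would stay equally close to these values, for example piperidin-1-yl, a piperazin-1-yl ring with its free amine, or an open-chain dimethylamino group. They also leave open how the series would read with a carbonyl in place of the thiocarbonyl, and whether either ring would matter there.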